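From diethylamino to dimethylamino: the expected effect on compound 3

A few compounds are considered here, and "the series" means these few. Any claim that something is new, unique, unknown or untested is made for them only; others in the source may bear on it.

Compound 1 `CCOC(=O)CN(C)C(=O)c1ccc(C(CC)(CC)c2ccc(OCC(O)C(C)(C)C)c(C)c2)n1CC`: 10100 nM
Compound 2 `CCN(CC)CCNC(=O)c1ccc(C(CC)(CC)c2ccc(OCC(O)C(C)(C)C)c(C)c2)n1CC`: 2500 nM

In an ADME assay on L02 cells (Homo sapiens) for cytotoxicity, read by MTT assay, with a stated time of 48 h (a lower number here means a stronger inhibitor, a higher number a weaker inhibitor), compound 2 holds the lower of the two numbers, at 2500 nM. Compound 3 `CCn1c(C(=O)NCCN(C)C)ccc1C(CC)(CC)c1ccc(OCC(O)C(C)(C)C)c(C)c1` differs from it by one change: dimethylamino in place of diethylamino on a saturated chain carbon, two bonds along the chain from an amide-type nitrogen. Dimethylamino stands in place of diethylamino on a saturated chain carbon, two bonds along the chain from an amide-type nitrogen. Within the data shown here, only one measured step bears on this, and only loosely: a 4.0-fold lower number from compound 1 to compound 2 (0.61 log units; beyond the scatter). Among the measured compounds shown here, that step swapped a different pair of groups, and no measurement yet tests this exact change. The expected result is a 1.2-fold higher number from compound 2 to compound 3 (0.08 log units; within the scatter), which would be no step beyond the scatter. Compound 3 is estimated at 3000 nM, with an expected range of 1300 nM to 7000 nM.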

Compound 3, half-maximal inhibitory concentration: 2600 nM
For compound 3 the middle estimate is 1.2-fold (0.06 log units) above the measured one; the measured number falls inside the stated range.
By their numbers in this assay, from the lowest: compounds 2 and 3 (each within the scatter of the next); then compound 1.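

In this assay, replacing diethylamino with dimethylamino on this saturated chain carbon gives a 1.0-fold higher number from compound 2 to compound 3 (0.02 log units; within the scatter) and so leaves compound 2 and compound 3 within the scatter of each other. The separation from compound 1 therefore does not rest on the ethyl groups, as a 3.9-fold lower number from compound 1 to compound 3 (0.59 log units; beyond the scatter) still lies beyond the scatter. No measured evidence accounts for either step. On these data alone, it remains open whether a cyclic amine such as pyrrolidine or morpholine in this place would give a similar number. As far as these compounds go, a longer chain between the amide nitrogen and the amine is equally open.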